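The source may hold more compounds than are shown below. What is called first, only, known or untested is meant among the compounds shown, and "the series" means these compounds.

Of the compounds shown here, three sharing a closely related core have been tested in an ADME assay on MT4 cells (Homo sapiens) for activation, read by MTT assay (on this read-out higher numbers stand for lower toxicity in this test and lower numbers for higher toxicity in this test), and none of them gives a number. Compound 1 `CCCCSc1nc(C(C)c2c(F)cccc2Cl)cc(=O)[nH]1` is reported only as a limit, > 73000 nM. Compound 2 `CCC(c1nc(SC(C)C)[nH]c(=O)c1C)c1c(F)cccc1Cl` is likewise reported only as a limit, > 3000 nM. Compound 3 `CCC(c1nc(SC(C)C)[nH]c(=O)c1C)c1c(F)cccc1F`, the starting point here, also stands only as a limit, > 30000 nM, so its place among the three cannot be ranked.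

Compound 4 `CCC(C)Sc1nc(C(CC)c2c(F)cccc2F)c(C)c(=O)[nH]1` has not yet been measured in this assay. It differs from compound 3 by methyl in place of hydrogen on a saturated chain carbon, two bonds along the chain from a sulfur, which turns isopropylsulfanyl into (sec-butyl)sulfanyl. Within the data shown here, the only measured step available is a step that the two limits leave unreadable from compound 2 to compound 3. That step concerns fluoro in place of chloro on an aromatic carbon, and it offers no size to carry over to this change. The expectation therefore rests on compound 3, whose limit is > 30000 nM, and no step beyond the usual scatter is expected, in either direction. The step expected is a number no higher from compound 3 to compound 4 (the limit leaves the size open). Compound 4 is estimated at 30000 nM, with an expected range from 8000 nM to 100000 nM.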

Compound 4, half-maximal cytotoxic concentration: > 3000 nM
Compound 4: no number, only a limit; the forecaster's own chance of this, stated with the estimate: 65%; the middle value lies beyond the limit too.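

In this assay compound 4 is reported only as a limit, > 3000 nM. Compound 3 is also reported only as a limit, > 30000 nM, so no step can be read between compound 3 and compound 4. The compounds shown leave open whether turning isopropylsulfanyl into (sec-butyl)sulfanyl shifts the half-maximal cytotoxic concentration at all, in either direction.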